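Shortening the amide chain to an ethynyl group

A few compounds are considered here, and "the series" means these few. Any claim that something is new, unique, unknown or untested is made for them only; others in the source may bear on it.

Of the compounds shown here, three built on one shared core have been measured in a functional assay on KYSE-450 cells (Homo sapiens) for inhibition, read by MTT assay, with a stated time of 48 h; a higher number here means a weaker inhibitor, a lower number a stronger inhibitor. Compound 1 `CCC/C=C/C(=O)N(Cc1ccc(OC)c(O)c1)c1cc(OC)c(OC)c(OC)c1` gives 57 nM, compound 2 `CCC(=O)N(Cc1ccc(OC)c(O)c1)c1cc(OC)c(OC)c(OC)c1` gives 98 nM, and compound 3 `C/C=C/C=C/C(=O)N(Cc1ccc(OC)c(O)c1)c1cc(OC)c(OC)c(OC)c1` gives 180 nM. Compound 3 thus carries the highest of the three numbers; the gap is a 3.2-fold higher number from compound 1 to compound 3 (0.50 log units; beyond the scatter), while a 1.8-fold higher number from compound 2 to compound 3 (0.26 log units; within the scatter) stays within the usual spread.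

Compound 4 `C#CC(=O)N(Cc1ccc(OC)c(O)c1)c1cc(OC)c(OC)c(OC)c1` is not yet measured. It differs from compound 3 in one place: ethynyl in place of penta-1,3-dien-1-yl on a carbonyl carbon. Among the measured compounds shown here, the steps that bear on this all change the group on the carbonyl carbon. Compound 1 to compound 2 gave a 1.7-fold higher number from compound 1 to compound 2 (0.24 log units; within the scatter) and compound 2 to compound 3 gave a 1.8-fold higher number from compound 2 to compound 3 (0.26 log units; within the scatter), so exchanging these chains has so far moved the numbers only modestly at most. The entering ethynyl is small, like the ethyl of compound 2, so compound 4 is expected to land near compound 2 because of 98 nM, a step of about a 1.8-fold lower number from compound 3 to compound 4 (0.26 log units; within the scatter). The estimate for compound 4 is 100 nM, expected to fall between 40 nM and 250 nM.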

Compound 4, half-maximal inhibitory concentration: 570 nM
Beside the measured number, compound 4's estimate is 5.7-fold (0.76 log units) below it, outside the stated range (above it).
By their numbers in this assay, from the lowest: compounds 1, 2 and 3 (each within the scatter of the next, the first and the last beyond it); then compound 4.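

In this assay the group on the carbonyl carbon matters more than the earlier chains suggested: ethynyl in place of penta-1,3-dien-1-yl gives a 3.2-fold higher number from compound 3 to compound 4 (0.50 log units; beyond the scatter) and ethynyl in place of pent-1-en-1-yl gives a 10-fold higher number from compound 1 to compound 4 (1.00 log units; beyond the scatter) as the largest gap in the set. A short group here does not by itself keep the number low, since ethynyl in place of ethyl gives a 5.8-fold higher number from compound 2 to compound 4 (0.76 log units; beyond the scatter) even though both groups are small. Nothing available here explains why ethynyl gives the weakest inhibitor of the four.

As far as these compounds go, whether the loss goes with the triple bond itself or with its shortness remains open, and a longer chain containing a triple bond would separate the two. From the compounds shown here alone, how an amine at the end of the chain would compare also remains open.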